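The compounds below may be only part of what the source reports. "The series", "measured", "known", "first", "only" and "open" are said of these compounds alone.

Measured in an ADME assay on THP-1 cells (Homo sapiens) for cytotoxicity, read by resazurin assay, with a stated time of 48 h (a higher number here means a weaker inhibitor, a lower number a stronger inhibitor), so far:
compound 1 `O=c1c(O)cccn1Cc1ccc(-c2ccccc2)cc1` gives > 10 ug/mL as a limit
compound 2 `N#Cc1cccc(-c2ccc(Cn3cccc(O)c3=O)cc2)c1` gives > 10 ug/mL as a limit

Compound 1 has no number, only the limit > 10 ug/mL in this assay. Among the compounds with values here, the series so far offers only the limit of > 10 ug/mL in this assay, at which 2 of the 2 values shown sit, and nothing finer. Within the data shown here, compound 3 `N#Cc1ccccc1-c1ccc(Cn2cccc(O)c2=O)cc1` departs from compound 1 by cyano in place of hydrogen on an aromatic carbon as its single change. Among the measured compounds shown here, the only measured step with the same swap is a step that the two limits leave unreadable from compound 1 to compound 2 and it gives no size to carry over. In this assay the expected step that the limit leaves unreadable from compound 1 to compound 3 stays within the scatter, with no direction favoured. Compound 3 is expected near 15 ug/mL within an estimated range of 8 ug/mL to 30 ug/mL and may well report as a limit again.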

Compound 3, half-maximal inhibitory concentration: > 10 ug/mL
Compound 3 was reported as a limit; the forecaster's own chance of this, stated with the estimate: 85%; the middle value lies beyond the limit too.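

Compound 1 and compound 3 both stand only as limits in this assay, so no step between them can be read: the limit of > 10 ug/mL in this assay, at which 3 of the 3 values shown sit.

The compounds shown leave open whether cyano in place of hydrogen on an aromatic carbon shifts the read-out at all, and by how much, in this assay.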